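A Methyl for a Methoxy on the Sulfonyl Ring

The compounds below may be only part of what the source reports. "The series", "measured", "known", "first", "only" and "open" are said of these compounds alone.

Measured so far:
compound 1, `COc1n[nH]c2ncc(-c3cn(-c4c(F)ccc(NC(=O)c5cccc(Cl)c5)c4F)nn3)cc12`: 54.3 nM
compound 2, `COc1cccc(S(=O)(=O)Nc2ccc(F)c(-n3cc(-c4cnc5[nH]nc(OC)c5c4)nn3)c2F)c1`: 2.3 nM

Both were tested in an assay on Sf9 cells for inhibition of mitogen-activated protein kinase kinase kinase 20 (Homo sapiens), read by ADP-Glo, with a stated time of 30 min; a higher number here means a weaker inhibitor, a lower number a stronger inhibitor. Among the measured compounds shown here, of the two numbers, compound 2 has the lower one, and its only neighbour is compound 1, which stands higher by the step of a 24-fold lower number from compound 1 to compound 2 (1.37 log units; beyond the scatter). That step exchanged the whole group on the ring nitrogen, an amide for a sulfonamide, and says nothing about small changes on the sulfonyl ring itself.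

The next compound, compound 3, is `COc1n[nH]c2ncc(-c3cn(-c4c(F)ccc(NS(=O)(=O)c5cccc(C)c5)c4F)nn3)cc12`. It differs from compound 2 by methyl in place of methoxy on an aromatic carbon. For the measured compounds named here, no measured step covers this kind of exchange, so nothing among the numbers points clearly either way. The expectation is therefore a step that stays within the usual scatter, a 1.3-fold higher number from compound 2 to compound 3 (0.12 log units; within the scatter). Compound 3 is estimated at 3 nM, with a range from 1 nM to 10 nM.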

Compound 3, half-maximal inhibitory concentration: 4.4 nM
The estimate for compound 3 lay 1.5-fold (0.17 log units) below the measured number; the range from low to high includes it.
By their numbers in this assay, from the lowest: compounds 2 and 3 (each within the scatter of the next); then compound 1.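

In this assay, methyl in place of methoxy on the sulfonyl ring gives a 1.9-fold higher number from compound 2 to compound 3 (0.28 log units; within the scatter) and so stays within the scatter, which means that at this position the oxygen of the methoxy can go without a clear change in the number. The large gain over the amide is also not tied to methoxy, since a 12-fold lower number from compound 1 to compound 3 (1.09 log units; beyond the scatter) accompanies a 24-fold lower number from compound 1 to compound 2 (1.37 log units; beyond the scatter) as a second step of the same kind, though each of these steps swaps the chloro-bearing carbonyl group as a whole. Nothing available gives a reason for either result and the numbers alone stand here.

On these data alone, whether an amine, a carboxylic acid or a longer chain such as butoxy would stay as close at this position remains open. So does what a plain hydrogen there would give.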